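Compound 2 to compound 3: a dimethylphenyl isomer

The source may hold more compounds than are shown below. What is called first, only, known or untested is meant among the compounds shown, and "the series" means these compounds.

Compound 1 `COc1cc2c(cc1OC)CN(CCn1cc(COc3ccc(C)cc3)nn1)CC2` gives > 100000 nM in an ADME assay on K562/A02 cells (Homo sapiens) for cytotoxicity, read by MTT assay, with a stated time of 48 h (on this read-out higher numbers stand for weaker inhibition and lower numbers for stronger inhibition), which is a limit of the assay and not a number. Compound 2 `COc1cc2c(cc1OC)CN(CCn1cc(COc3ccc(C)c(C)c3)nn1)CC2` gives > 100000 nM in this assay, which is also a limit. The pair therefore offers no numerical reference point: the limit of > 100000 nM in this assay, at which 2 of the 2 values shown sit.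

Compound 3 `COc1cc2c(cc1OC)CN(CCn1cc(COc3ccc(C)cc3C)nn1)CC2` has the same atoms as compound 2, joined differently: 2,4-dimethylphenyl in place of 3,4-dimethylphenyl on an oxygen on a saturated carbon. In words, 2,4-dimethylphenyl stands in place of 3,4-dimethylphenyl on an oxygen on a saturated carbon.

Within the data shown here, only one measured step bears on this change: a step that the two limits leave unreadable from compound 1 to compound 2. That step places methyl in place of hydrogen on an aromatic carbon, and it gives no size to carry forward. With no readable step in the series, no change beyond the scatter is expected in this assay, and no direction can be assigned. The expected step is a step that the limit leaves unreadable from compound 2 to compound 3. A report of a limit alone is the likeliest outcome for compound 3. For compound 3 the estimated value is 120000 nM, with an expected range of 60000 nM to 250000 nM.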

Compound 3, half-maximal inhibitory concentration: > 100000 nM
Compound 3: a limit, no number (the forecaster's own chance of this, stated with the estimate: 85%); the middle value is on the limit's open side.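

In this assay, among these compounds, compound 3 gives > 100000 nM, which is a limit and not a number, so no step among compound 1, compound 2 and compound 3 can be read. The compounds shown leave open whether these three differ at all, and which change, if any, would bring a value inside the limit.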